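Adding a Third Methoxy Group to an Inactive Series

The compounds below may be only part of what the source reports. "The series", "measured", "known", "first", "only" and "open" are said of these compounds alone.

Compound 1 `COc1ccccc1CNc1ncnc2c1ncn2C1CCCCO1` was examined in an ADME assay on MCF7 cells (Homo sapiens) for cytotoxicity, with a stated time of 72 h; a lower number here means a stronger inhibitor, a higher number a weaker inhibitor. In this assay compound 1 gives only a limit, > 100000 nM. Compound 2 `COc1cccc(OC)c1CNc1ncnc2c1ncn2C1CCCCO1` carries the change (methoxy in place of hydrogen on an aromatic carbon). In this assay compound 2 likewise gives only a limit, > 100000 nM. The step that the two limits leave unreadable from compound 1 to compound 2 cannot be read because both ends sit at the limit of > 100000 nM in this assay, at which 2 of the 3 values shown sit. Compound 3 `COc1ccc(OC)c(CNc2ncnc3c2ncn3C2CCCO2)c1` has a different core from compound 1; the difference between the two cores is not broken down here. In this assay compound 3 also gives only a limit, > 50000 nM, which is the limit of > 50000 nM in this assay, at which 1 of the 3 values shown sits.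

Compound 4 `COc1cc(OC)c(OC)cc1CNc1ncnc2c1ncn2C1CCCO1` differs from compound 3 by methoxy in place of hydrogen on an aromatic carbon. This is the same kind of change as that from compound 1 to compound 2, but the place differs: here the entering methoxy sits ortho to a methoxy group, meta to a methoxy group and para to a large group, whereas in compound 2 it sits ortho to a large group and meta to a methoxy group. Every measured compound reaches only a limit, and the earlier step gives no readable size; on that rests the expected step that the limit leaves unreadable from compound 3 to compound 4, estimated to be small. Compound 4 is expected to give 100000 nM in this assay, most likely again as a limit, with a range from 30000 nM to 300000 nM.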

Compound 4, half-maximal inhibitory concentration: > 100000 nM
Compound 4: no number, only a limit; the forecaster's own chance of this, stated with the estimate: 85%; the middle value lies on the limit itself.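

In this assay, compound 3 and compound 4 both give only limits, so no size can be read for the step from compound 3 to compound 4. The compounds shown leave open how far any of them lies past its limit, and whether methoxy in place of hydrogen on an aromatic carbon changes the read-out at all.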